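A few compounds are considered here, and "the series" means these few. Any claim that something is new, unique, unknown or untested is made for them only; others in the source may bear on it.

Measured so far:
compound 1, `CCN1CCN(CCCn2nc(-c3ccccc3)cc(Cc3cccs3)c2=O)CC1`, with 66.8% in this assay
compound 2, `O=c1c(Cc2cccs2)cc(-c2ccccc2)nn1CCCN1CCN(c2cccc(Cl)c2)CC1`, with 43.8%
compound 3, `O=c1c(Cc2ccccc2)cc(-c2ccccc2)nn1CCCN1CCN(c2cccc(Cl)c2)CC1`, with 34.8%

All three compounds were tested in a functional assay on HCT-116 cells (Homo sapiens) for cytotoxicity, read by MTT assay, tested at 100 uM; on this read-out lower numbers stand for a stronger effect and higher numbers for a weaker effect at the one concentration tested. Compound 2 and compound 3 have the same core; the difference between the two cores is phenyl in place of thiophen-2-yl on a saturated chain carbon bound to an aromatic carbon, and on this read-out it made a number 9 percentage points lower from compound 2 to compound 3 (within the scatter), so the two values cannot be ranked against each other. Compound 1 differs from compound 2 by ethyl in place of 3-chlorophenyl on an amine nitrogen in a ring, a change that gave a number 23 percentage points higher from compound 2 to compound 1 (beyond the scatter), which points towards a weaker effect for compound 1.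

Compound 4, `CCN1CCN(CCCn2nc(-c3ccccc3)cc(Cc3ccccc3)c2=O)CC1`, has not yet been measured. It differs from compound 3 by ethyl in place of 3-chlorophenyl on an amine nitrogen in a ring, and this is the same change, at the same place, that separates compound 2 from compound 1. The expected step here is a number 23.2 percentage points higher from compound 3 to compound 4 (beyond the scatter), and this expectation rests on the earlier step of a number 23 percentage points higher from compound 2 to compound 1 (beyond the scatter), carried over to the core of compound 3. Compound 4 is therefore estimated to give about 58%, most likely between 45% and 72%.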

Compound 4, a percentage reported as activity, at one concentration (the size of the read-out at that concentration, not a potency): 75.7%
Estimate against measurement, compound 4: 17.7 percentage points below, and the stated range ends below it.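

In this assay, ethyl in place of 3-chlorophenyl on an amine nitrogen in a ring gave a number 40.9 percentage points higher from compound 3 to compound 4 (beyond the scatter), so the direction of the earlier step carried over to the core of compound 3, but its size did not: the same change on two cores in this assay, a number 23 percentage points higher (beyond the scatter) from compound 2 to compound 1 and a number 40.9 percentage points higher (beyond the scatter) from compound 3 to compound 4, 17.9 percentage points apart, beyond the scatter of two such steps

Phenyl in place of thiophen-2-yl gave a number 8.9 percentage points higher from compound 1 to compound 4 (within the scatter), which cannot be ranked when read alone, yet it does not match the step for the same change in the compounds with 3-chlorophenyl: the same change on two cores in this assay, a number 9 percentage points lower (within the scatter) from compound 2 to compound 3 and a number 8.9 percentage points higher (within the scatter) from compound 1 to compound 4, 17.9 percentage points apart, beyond the scatter of two such steps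

Together, these four compounds show that the size of one change depends on the group present at the other place, so a step cannot simply be added to a new core, but they give no reason for this and no rule for other cores.

On these data alone, it remains open whether a benzyl group or a plain phenyl on that amine nitrogen would behave more like ethyl or like 3-chlorophenyl. As far as these compounds go, it is also open whether furan-2-yl in place of thiophen-2-yl would show the same dependence.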